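The source may report more compounds than this note shows. Statements on the series, on what has been measured and on what is new or still open speak of the compounds shown alone.

Series notes. In a functional assay on the whole organism (artery, strain albino) with Rattus norvegicus as the target, with a stated time of 360 min, at a dose of 10 mg/kg by the oral route (a lower number here means less inhibition, a higher number more inhibition at the dose given (going by the name of the read-out)), compound 1 `CC1=C(C(=O)Nc2ccc(Br)cc2)C(c2ccc(Cl)cc2Cl)N=C(SCc2ccc(Cl)cc2)N1` gives 39.7%, and compound 2 `CC1=C(C(=O)Nc2ccc(Br)cc2)C(c2ccc(Cl)cc2Cl)N=C(SCc2ccc(F)cc2)N1` gives 40.7%. The change from the first to the second is fluoro in place of chloro on an aromatic carbon, and the step it made is a number 1 percentage points higher from compound 1 to compound 2 (within the scatter). Compound 3 `CC1=C(C(=O)Nc2ccc([N+](=O)[O-])cc2)C(c2ccc(Br)cc2)N=C(SCc2ccc(Cl)cc2)N1` gives 39.2% in this assay; its number and those of compound 1 and compound 2 all lie within the usual scatter of one another, so no order among the three is claimed. The difference between the core of compound 3 and the core of compound 1 is not broken down here. Compound 4 `CC1=C(C(=O)Nc2ccc([N+](=O)[O-])cc2)C(c2ccc(Br)cc2)N=C(SCc2ccc(F)cc2)N1` has not yet been measured in this assay. It differs from compound 3 by fluoro in place of chloro on an aromatic carbon, the same change that turns compound 1 into compound 2, made at the same place in both pairs. Since the step of a number 1 percentage points higher from compound 1 to compound 2 (within the scatter) showed no movement beyond the scatter, a similarly flat step is expected here, namely a number 0.8 percentage points higher from compound 3 to compound 4 (within the scatter). The estimate for compound 4 in this assay is therefore 40%, expected to fall between 30% and 50%.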

Compound 4, a percentage reported as inhibition, in the whole organism at one dose (the size of the read-out at that dose, not a potency): 38.7%
Compound 4: the middle estimate sits 1.3 percentage points above what was measured; the range from low to high includes it.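

In this assay, the change from (4-chlorobenzyl)sulfanyl to (4-fluorobenzyl)sulfanyl on the core of compound 3 gives a number 0.5 percentage points lower from compound 3 to compound 4 (within the scatter). Set beside the same change on the core of compound 1, the step stays flat on both cores, and the two steps do not differ: the same change on two cores in this assay, a number 1 percentage points higher (within the scatter) from compound 1 to compound 2 and a number 0.5 percentage points lower (within the scatter) from compound 3 to compound 4, 1.5 percentage points apart, within the scatter of two such steps. This shows that, on these two cores and at this one dose, fluoro in place of chloro leaves no movement that can be told from the scatter, but it does not show that the two cores would respond alike to a change that did move the read-out, and it says nothing about potency.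

As far as these compounds go, all four compounds carry a halogen on the benzyl group, so it stays open whether another group at that place, such as an amine, a carboxylic acid or a methoxy group, would shift the read-out. From the compounds shown here alone, the two cores differ in more than one place, so what each of those differences contributes on its own also stays open.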